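From Methylsulfanyl to Dimethylamino on Compound 1

The source may report more compounds than this note shows. Statements on the series, on what has been measured and on what is new or still open speak of the compounds shown alone.

Compound 1 `CSc1ncnc2c1c(-c1ccoc1)cn2[C@@H]1O[C@H](CO)[C@@H](O)[C@H]1O`: 360 nM
Compound 2 `CSc1ncnc2c1c(-c1ccccc1)cn2[C@@H]1O[C@H](CO)[C@@H](O)[C@H]1O`: > 20000 nM (a limit)

For the measured compounds named here, in a functional assay on HL-60 cells (Homo sapiens) for antiproliferative activity, read by XTT assay, with a stated time of 72 h (a lower number here means a stronger inhibitor, a higher number a weaker inhibitor), compound 1 gives 360 nM, the only actual number so far. For compound 2, > 20000 nM is a limit of the assay. Compound 3 `CN(C)c1ncnc2c1c(-c1ccoc1)cn2[C@@H]1O[C@H](CO)[C@@H](O)[C@H]1O` differs from compound 1 as follows: dimethylamino in place of methylsulfanyl on an aromatic carbon. Going by the values given here, the sole measured step, an at least 55-fold higher number from compound 1 to compound 2 (1.74 log units; beyond the scatter), is large, but it lies at the furan-3-yl group, so it bears only indirectly on this change. It does show that one substitution can shift this assay strongly. A moderate rise, beyond the scatter, is expected, with an estimated 6.9-fold higher number from compound 1 to compound 3 (0.84 log units; beyond the scatter). The expected value for compound 3 is 2500 nM, with an estimated range of 400 nM to 15000 nM.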

Compound 3, half-maximal inhibitory concentration: 1160 nM
The estimate for compound 3 lay 2.2-fold (0.33 log units) above the measured number; measured number inside the range.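

In this assay, the step at this aromatic carbon is a 3.2-fold higher number from compound 1 to compound 3 (0.51 log units; beyond the scatter), so dimethylamino in place of methylsulfanyl weakens the compound modestly without abolishing activity. For the compounds shown here, this is the only reading at this position, and the furan-3-yl group stays the same across it. Compound 3 gives a true number, clear of the one limit in the series: the limit of > 20000 nM in this assay, at which 1 of the 3 values shown sits.

Going by these compounds, whether a primary amine, a methoxy group or a longer chain such as ethylsulfanyl would do better here stays open. So does whether this step would hold with phenyl in place of furan-3-yl.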